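This account rests on a few compounds, and the source may have more. Where it says the series, first, only, none or still open, it means among the compounds named here.

Measured in a functional assay on HCT-116 cells (Homo sapiens) for antiproliferative activity, read by sulforhodamine B assay, with a stated time of 72 h; a lower number here means a stronger inhibitor, a higher number a weaker inhibitor:
- compound 1 `Cn1cc(-c2ccc(=O)n(CCOc3ccnc4cc(OCCCC(=O)NO)ccc34)n2)cn1`: > 10000 nM
- compound 2 `Cn1cc(-c2ccc(=O)n(CCOc3ccnc4cc(OCCCCCCC(=O)NO)ccc34)n2)cn1`: > 10000 nM

Compound 2 stands at > 10000 nM, which is a limit and not a number. For the measured compounds named here, the whole series so far sits at the limit of > 10000 nM in this assay, at which 2 of the 2 values shown sit. Going by the values given here, the only measured step, a step that the two limits leave unreadable from compound 1 to compound 2, has no readable size.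

Compound 3 `Cn1cc(-c2ccc(=O)n(CCOc3ccnc4cc(OCCCCCC(=O)Nc5ccccc5N)ccc34)n2)cn1` differs from compound 2 as follows: (2-aminophenyl)carbamoyl in place of (hydroxycarbamoyl)methyl on a saturated chain carbon, five bonds along the chain from an oxygen on an aromatic ring. Here (2-aminophenyl)carbamoyl replaces (hydroxycarbamoyl)methyl on a saturated chain carbon, five bonds along the chain from an oxygen on an aromatic ring. Among the compounds with values here, no measured step covers this exchange. Resting on a step that the two limits leave unreadable from compound 1 to compound 2, no shift beyond the scatter is expected in this assay, in either direction, and another limit is likely. The estimated step is a step that the limit leaves unreadable from compound 2 to compound 3. Compound 3 is expected at 12000 nM, within 4000 nM to 36000 nM.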

Compound 3, half-maximal inhibitory concentration: 7000 nM
The estimate for compound 3 lay 1.7-fold (0.23 log units) above the measured number, and the stated range covers the measured number.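

In this assay, for the compounds shown here, (2-aminophenyl)carbamoyl at this place gives the only number so far, with compound 3 at 7000 nM. As far as these compounds go, the exchange amounts to an at least 1.4-fold lower number from compound 2 to compound 3 (0.15 log units; that floor lies within the scatter) and, against the shorter hydroxamic acid, to an at least 1.4-fold lower number from compound 1 to compound 3 (0.15 log units; that floor lies within the scatter); neither floor establishes a shift beyond the scatter, and the true size of each step stays unknown. Compound 1 and compound 2 remain at a limit of the assay: the limit of > 10000 nM in this assay, at which 2 of the 3 values shown sit.

Open, from the compounds shown here alone, is whether a longer chain carrying the (2-aminophenyl)carbamoyl group would move the number. Also open, going by these compounds, is what a carboxylic acid at this place would give.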